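The source may report more compounds than this note shows. Statements on the series, on what has been measured and on what is new or still open speak of the compounds shown alone.

Working notes on the series. The shared core carries a phenyl group and two amino groups, and the compounds differ only at the group attached through an oxygen or a nitrogen. Compound 1 `Nc1cc(N)c2nc(-c3ccccc3)c(Oc3ccc(Cl)c(Cl)c3)nc2c1` carries a 3,4-dichlorophenyl through an ether oxygen; in a functional assay on OVCAR-5 cells (Homo sapiens) for inhibition, read by sulforhodamine B assay, with a stated time of 48 h (a lower number here means a stronger inhibitor of growth, a higher number a weaker inhibitor of growth), compound 1 gives 25100 nM. Compound 3 `Nc1cc(N)c2nc(-c3ccccc3)c(NCc3ccc(Cl)c(Cl)c3)nc2c1` carries the same 3,4-dichlorophenyl through a methylene and an amine nitrogen; in this assay compound 3 gives 24000 nM. Compound 3 and compound 1 sit within the scatter of each other, so the numbers show no difference between the ether and the amine link. Compound 2 `CCOC(=O)[C@H](CCC(=O)O)NC(=O)c1ccc(CNc2nc3cc(N)cc(N)c3nc2-c2ccccc2)cc1` carries a much larger benzylamine bearing an amide-linked ester chain. For compound 2 the result in this assay is a limit of the assay, < 100000 nM, not a number (the limit of < 100000 nM in this assay, at which 1 of the 3 values shown sits).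

Compound 4 `COc1ccc(CNc2nc3cc(N)cc(N)c3nc2-c2ccccc2)cc1OC` is not yet measured. Its change from compound 3 is 3,4-dimethoxyphenyl in place of 3,4-dichlorophenyl on a saturated chain carbon bound to a nitrogen on an aromatic ring. For the measured compounds named here, no measured pair isolates this change, so the size of the step is not known; the two numbers at hand lie close together, and the expectation is a step from compound 3 to compound 4 that is small or within the scatter, with a weaker result somewhat more likely than a stronger one. The estimated step is a 1.5-fold higher number from compound 3 to compound 4 (0.16 log units; within the scatter). For compound 4 in this assay the estimate is 35000 nM, within a range of 12000 nM to 100000 nM.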

Compound 4, concentration for 50% growth inhibition: 20900 nM
Estimate against measurement, compound 4: 1.7-fold (0.22 log units) above; measured number inside the range.
By their numbers in this assay, from the lowest: compounds 4, 3 and 1 (each within the scatter of the next).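

In this assay, 3,4-dimethoxyphenyl in place of 3,4-dichlorophenyl gives a 1.1-fold lower number from compound 3 to compound 4 (0.06 log units; within the scatter), so the number at this position does not respond to this exchange of the ring's substituents. The earlier pair of numbers spoke only to the link, whereas here the link stays the same and the group itself changes, from 8 heavy atoms and 0 hydrogen-bond acceptors to 10 heavy atoms and 2 hydrogen-bond acceptors, with the result still within the scatter. Nothing at hand gives a cause for this flat result.

The compounds shown leave open whether any group at this position can move the number beyond the scatter, for example a single fluorine or an amine on the ring, or a longer chain carrying the ring. Compound 2 stands at a limit of the assay, < 100000 nM, not a number, so steps to it cannot be read.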